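This account rests on a few compounds, and the source may have more. Where it says the series, first, only, none or still open, it means among the compounds named here.

Two compounds share one core here, and a third is still to be tested. Compound 1 `O=S(=O)(Nc1cc(-c2ccc3nc(NC4CC4)sc3c2)cnc1Cl)c1ccc(F)cc1` carries a cyclopropylamino group on that core, but in a functional assay on U-87MG ATCC cells for antiproliferative activity against U-87 MG (Homo sapiens), read by MTT assay, with a stated time of 72 h (on this read-out lower numbers stand for stronger inhibition and higher numbers for weaker inhibition), compound 1 gives "not determined" (no result reported), so no result was reported for it. Among the measured compounds shown here, compound 2 `CCN(CC)CCNC(=O)Nc1nc2ccc(-c3cnc(Cl)c(NS(=O)(=O)c4ccc(F)cc4)c3)cc2s1` is the only compound with a number: in this assay compound 2 gives 1390 nM, so it is the sole reference point, with nothing to compare it against.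

Compound 3 `O=C(Nc1nc2ccc(-c3cnc(Cl)c(NS(=O)(=O)c4ccc(F)cc4)c3)cc2s1)NC1CC1` differs from compound 2 in a single place (cyclopropyl in place of 2-(diethylamino)ethyl on an amide-type nitrogen). For the measured compounds named here, no pair of measured compounds shows what such a change does in this setting, so there is no measured step to lean on. With only the value of compound 2 as a footing, the expectation is for a small step, somewhat toward weaker inhibition, but one that could as easily sit within the ordinary scatter of repeated measurements as just beyond it. The step from compound 2 to compound 3 that this expectation means is a 1.6-fold higher number from compound 2 to compound 3 (0.20 log units; within the scatter). Compound 3 is therefore estimated at 2200 nM, with a range from 700 nM to 7000 nM.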

Compound 3, half-maximal inhibitory concentration: 1720 nM
Compound 3: the middle estimate sits 1.3-fold (0.11 log units) above what was measured; the range from low to high includes it.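

In this assay, putting cyclopropyl in place of 2-(diethylamino)ethyl on the amide-type nitrogen gives a 1.2-fold higher number from compound 2 to compound 3 (0.09 log units; within the scatter) and so leaves the two compounds indistinguishable on this read-out. Among the compounds shown here, this is the first sign of how the position behaves: a chain of 7 heavy atoms that includes a nitrogen and a three-membered carbon ring of 3 heavy atoms give results that cannot be told apart, so in this pair the nitrogen of the chain is not needed to reach a value of this size. No other measurement here speaks to why the two groups read alike.

Going by these compounds, only these two groups can be compared at this position, so it remains open whether the same tolerance would hold for a carboxylic acid at the end of the chain, a longer plain carbon chain, or a larger ring such as cyclohexyl. The role of the carbonyl also stays unresolved, since compound 1, which carries a cyclopropylamino group directly on the shared core, gives "not determined" (no result reported) in this assay and offers no number to set against the others.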